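Trifluoromethyl in place of chloro on the shared core

The source may hold more compounds than are shown below. What is called first, only, known or untested is meant among the compounds shown, and "the series" means these compounds.

Compounds measured in a functional assay on A549 cells (Homo sapiens) for inhibition, read by MTT assay, with a stated time of 72 h; a higher number here means a weaker inhibitor, a lower number a stronger inhibitor
Compound 1 `COc1cc(O)c(CC=C(C)C)c(O)c1C(=O)/C=C/c1ccc(C(F)(F)F)cc1` gives 11100 nM
Compound 2 `COc1cc(O)cc(O)c1C(=O)/C=C/c1ccc(C)cc1` gives > 50000 nM, which is a limit of the assay
Compound 3 `COc1cc(O)cc(O)c1C(=O)/C=C/c1ccc(Cl)cc1` gives 18200 nM

The values of compound 3 and compound 1 lie within the scatter of each other, so neither ranks ahead of the other. The only other result in the set is the limit for compound 2.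

The next compound is compound 4 `COc1cc(O)cc(O)c1C(=O)/C=C/c1ccc(C(F)(F)F)cc1`, which carries trifluoromethyl in place of chloro on an aromatic carbon.

Among the measured compounds shown here, one measured step bears on this change: an at least 2.7-fold lower number from compound 2 to compound 3 (0.43 log units; beyond the scatter). It shows that a swap on an aromatic carbon can move the number, but it replaces methyl, not chloro, so it gives no direct size for this change. Compound 1 also carries trifluoromethyl and gives 11100 nM, but its core differs from that of compound 4.

With this little evidence, the expected change in this assay is small and its direction is uncertain. The estimated step is a 1.1-fold lower number from compound 3 to compound 4 (0.06 log units; within the scatter), which is not expected to exceed the scatter. The estimate for compound 4 is 16000 nM, with an expected range from 7000 nM to 38000 nM.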

Compound 4, half-maximal inhibitory concentration: 15400 nM
Compound 4: middle estimate off by 1.0-fold (0.02 log units), on the high side; the measured number falls inside the stated range.
By their numbers in this assay, from the lowest: compounds 1, 4 and 3 (each within the scatter of the next). At a limit, above all of these: compound 2.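

In this assay, trifluoromethyl and chloro on this aromatic carbon, para to a large group, are not separated, as the step stays within the scatter (a 1.2-fold lower number from compound 3 to compound 4 (0.07 log units; within the scatter)). Methyl is the one group of the three that stands apart, since trifluoromethyl in its place gives a step beyond the scatter (an at least 3.2-fold lower number from compound 2 to compound 4 (0.51 log units; beyond the scatter)), though that step is only a bound because compound 2 sits at a limit of the assay: the limit of > 50000 nM in this assay, at which 1 of the 4 values shown sits. With trifluoromethyl held fixed, hydrogen in place of 3-methylbut-2-en-1-yl on the other aromatic carbon also leaves the number within the scatter (a 1.4-fold higher number from compound 1 to compound 4 (0.14 log units; within the scatter)), so this pair gives no sign that the chain matters in this assay.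

Still open, going by these compounds, is whether any group at the position para to the large group can move the number beyond the values of compound 3 and compound 4, for instance an amine, a carboxylic acid or a nitrile. Also open, on these data alone, is whether a longer chain or a hydroxyl group in place of 3-methylbut-2-en-1-yl would separate from hydrogen, and whether the result for that chain holds with chloro in place of trifluoromethyl.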